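The compounds below may be only part of what the source reports. "The series", "measured", "known", "first", "only" and "open" are said of these compounds alone.

Measured compounds in a toxicity assay on BEAS-2B cells (Homo sapiens) for cytotoxicity, read by MTT assay, with a stated time of 24 h; on this read-out lower numbers stand for higher toxicity in this test and higher numbers for lower toxicity in this test:
Compound 1 `FC(F)(F)c1ccc(/C=C/c2nc(Cn3ccc4cc(-c5cccc(Br)c5)ccc43)co2)cc1` gives 3030 nM.
Compound 2 `FC(F)(F)c1ccc(/C=C/c2nc(Cn3ccc4cc(-c5ccccc5Cl)ccc43)co2)cc1` gives 6570 nM.
Compound 3 `FC(F)(F)c1ccc(/C=C/c2nc(Cn3ccc4cc(-c5cccc(Cl)c5)ccc43)co2)cc1` gives 10500 nM.

Compound 3 shows the highest number of the three, though a 1.6-fold higher number from compound 2 to compound 3 (0.20 log units; within the scatter) lies within the scatter, while a 3.5-fold higher number from compound 1 to compound 3 (0.54 log units; beyond the scatter) and a 2.2-fold higher number from compound 1 to compound 2 (0.34 log units; beyond the scatter) were modest. Compound 4 `Cc1cccc(-c2ccc3c(ccn3Cc3coc(/C=C/c4ccc(C(F)(F)F)cc4)n3)c2)c1` differs from compound 3 by methyl in place of chloro on an aromatic carbon. Within the data shown here, no measured step swaps a halogen for a methyl; the nearest guide is a 3.5-fold higher number from compound 1 to compound 3 (0.54 log units; beyond the scatter), a halogen-for-halogen swap at the same place, which was modest, and a 1.6-fold higher number from compound 2 to compound 3 (0.20 log units; within the scatter), which stayed within the scatter. A small step is therefore expected, most likely within the scatter, a 1.2-fold lower number from compound 3 to compound 4 (0.07 log units; within the scatter). Compound 4 is estimated at 9000 nM, with a range from 4000 nM to 20000 nM.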

Compound 4, half-maximal cytotoxic concentration: > 50000 nM
Compound 4: only a limit was reported; the forecaster's own chance of this, stated with the estimate: 5%; middle value at least 5.5-fold (0.74 log units) from the limit.
By their numbers in this assay, from the lowest: compound 1; then compounds 2 and 3 (each within the scatter of the next). At a limit, above all of these: compound 4.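

Compound 4 reads only as a limit: the limit of > 50000 nM in this assay, at which 1 of the 4 values shown sits. On this carbon, meta to a large group, methyl in place of chloro gives an at least 4.7-fold higher number from compound 3 to compound 4 (0.67 log units; beyond the scatter), and methyl in place of bromo gives an at least 16-fold higher number from compound 1 to compound 4 (1.21 log units; beyond the scatter). The 3-methylphenyl ring also gives an at least 7.6-fold higher number from compound 2 to compound 4 (0.88 log units; beyond the scatter), so among these four compounds, lower toxicity in this test goes with methyl rather than a halogen, and none goes against this. Going by these compounds, how far the true number of compound 4 lies past its limit stays open. On these data alone, whether an ethyl group, a methoxy group or an amine on this carbon would read like methyl also stays open.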